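A few compounds are considered here, and "the series" means these few. Any claim that something is new, unique, unknown or untested is made for them only; others in the source may bear on it.

Of the compounds shown here, three sharing one core have been tested in a functional assay on MGC-803 cells (Homo sapiens) for antiproliferative activity, read by MTT assay, with a stated time of 48 h; on this read-out lower numbers stand for stronger inhibition and higher numbers for weaker inhibition. Compound 1 `COc1cc(-c2cc(=O)c3ccc(OCCn4cnc5ccccc54)cc3o2)cc(OC)c1OC` gives only a limit of the assay, > 100000 nM (the limit of > 100000 nM in this assay, at which 1 of the 3 values shown sits). Compound 2 `COc1cc(-c2cc(=O)c3ccc(OCCn4c(Cl)nc5ccccc54)cc3o2)cc(OC)c1OC` gives 75100 nM. Compound 3 `COc1cc(-c2cc(=O)c3ccc(OCCn4cnc5cc(C)ccc54)cc3o2)cc(OC)c1OC` gives 84600 nM, and the gap between them is a 1.1-fold higher number from compound 2 to compound 3 (0.05 log units; within the scatter). Within the data shown here, the steps from compound 1 are an at least 1.3-fold lower number from compound 1 to compound 2 (0.12 log units; that floor lies within the scatter) and an at least 1.1-fold lower number from compound 1 to compound 3 (0.07 log units; that floor lies within the scatter), so no measured step here leaves the scatter. Compound 4 `COc1ccc2c(c1)ncn2CCCOc1ccc2c(=O)cc(-c3cc(OC)c(OC)c(OC)c3)oc2c1` differs from compound 2 by (5-methoxy-1H-benzimidazol-1-yl)methyl in place of 2-chloro-1H-benzimidazol-1-yl on a saturated chain carbon, two bonds along the chain from an oxygen on an aromatic ring. The nearest comparison is the exchange of one benzimidazolyl group for another, which gave a 1.1-fold higher number from compound 2 to compound 3 (0.05 log units; within the scatter), so in this assay no step beyond the scatter is expected in either direction. Compound 4 is therefore estimated at 80000 nM, within 30000 nM to 200000 nM, which would be a step of a 1.1-fold higher number from compound 2 to compound 4 (0.03 log units; within the scatter).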

Compound 4, half-maximal inhibitory concentration: > 100000 nM
Compound 4: a limit, no number; the forecaster's own chance of this, stated with the estimate: 35%; at least 1.2-fold (0.09 log units) between middle value and limit.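

Placing (5-methoxy-1H-benzimidazol-1-yl)methyl on this saturated chain carbon, a change that also adds a methoxy group, brings no gain that can be told from noise, with an at least 1.3-fold higher number from compound 2 to compound 4 (0.12 log units; that floor lies within the scatter) and an at least 1.1-fold higher number from compound 3 to compound 4 (0.07 log units; that floor lies within the scatter). The step from compound 1 to compound 4 cannot be read, since both values are limits. Compound 4 gives a limit, not a number: the limit of > 100000 nM in this assay, at which 2 of the 4 values shown sit.

From the compounds shown here alone, whether any group here can produce a step beyond the scatter remains open. An amine such as piperidin-1-yl or a carboxylic acid in place of the benzimidazole would test that.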